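This account rests on a few compounds, and the source may have more. Where it says the series, first, only, none or still open, it means among the compounds named here.

Measured so far:
compound 1, `CC(C)C[C@@H](N)CN(C(=O)[C@@H]1C[C@H]1c1ccccc1)c1ccc(-c2ccccc2)cc1`, gives 1.8 nM in a functional assay for agonist activity at G protein-coupled receptor 88 (Homo sapiens), read by HTRF and cAMP accumulation; a lower number here means that less compound is needed, a higher number that more compound is needed for the effect.
compound 2, `N[C@H](CN(C(=O)[C@@H]1C[C@H]1c1ccccc1)c1ccc(-c2ccccc2)cc1)C1CCCCC1`, gives 0.66 nM in this assay.

Compound 2 holds the lower of the two numbers; the step of a 2.7-fold lower number from compound 1 to compound 2 (0.44 log units; beyond the scatter) separates it from compound 1. Compound 3, `NC1(CN(C(=O)[C@@H]2C[C@H]2c2ccccc2)c2ccc(-c3ccccc3)cc2)CCCC1`, carries 1-aminocyclopentyl in place of amino(cyclohexyl)methyl on a saturated chain carbon bound to an amide-type nitrogen. Among the compounds with values here, the only measured step, a 2.7-fold lower number from compound 1 to compound 2 (0.44 log units; beyond the scatter), exchanged 1-amino-3-methylbutyl for amino(cyclohexyl)methyl and was modest in size. Within the data shown here, it does not address a change in which the amine moves onto the carbon of a 1-aminocyclopentyl group and the defined stereocentre of compound 2 is lost, so no measured step speaks to the direction of this change. With that in mind, compound 3 is expected to give 3 nM in this assay, within a range of 0.7 nM to 15 nM. The expected step is a 4.5-fold higher number from compound 2 to compound 3 (0.66 log units; beyond the scatter), a somewhat higher number than for compound 2.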

Compound 3, half-maximal effective concentration: 0.57 nM
Beside the measured number, compound 3's estimate is 5.3-fold (0.72 log units) above it; measured number outside the range, below it.
By their numbers in this assay, from the lowest: compounds 3 and 2 (each within the scatter of the next); then compound 1.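

In this assay, within the data shown here, 1-aminocyclopentyl in place of amino(cyclohexyl)methyl on a saturated chain carbon bound to an amide-type nitrogen gives a 1.2-fold lower number from compound 2 to compound 3 (0.06 log units; within the scatter) and so leaves the number in place, even though the one defined stereocentre of compound 2 is gone and a five-membered ring stands for a six-membered one. Set against the open-chain 1-amino-3-methylbutyl group, the same 1-aminocyclopentyl group gives a 3.2-fold lower number from compound 1 to compound 3 (0.50 log units; beyond the scatter) in the same direction as the cyclohexyl-bearing group of compound 2, with compound 1 the only open-chain case. Nothing available here explains these numbers.

Ring size and the loss of the stereocentre changed together, so their separate contributions remain unknown. A 1-aminocyclohexyl group would keep the six-membered ring without a stereocentre, and a hydroxyl in place of the amine would test whether the amine is needed.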